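Replacing the 1,3-thiazol-2-yl group of compound 2

The compounds below may be only part of what the source reports. "The series", "measured", "known", "first", "only" and "open" are said of these compounds alone.

Measured in a functional assay on HL-60 cells (Homo sapiens) for cytotoxicity, read by MTT assay, with a stated time of 3 days; a lower number here means a stronger inhibitor, a higher number a weaker inhibitor:
- compound 1 (`CNc1nc(SCc2nc3ccccc3[nH]2)nc(-c2ccccc2)c1C#N`) gives 6.57 nM
- compound 2 (`N#Cc1c(Nc2nccs2)nc(SCc2nc3ccccc3[nH]2)nc1-c1ccccc1`) gives 11.9 nM

Going by the values given here, compound 2 lies within the scatter of compound 1, the only other measured compound. The change to compound 3 (`N#Cc1c(NNC(N)=S)nc(SCc2nc3ccccc3[nH]2)nc1-c1ccccc1`) is a group of 4 heavy atoms (1 carbon, 2 nitrogen, 1 sulfur; no ring) in place of a group of 5 heavy atoms (3 carbon, 1 nitrogen, 1 sulfur; one five-membered aromatic ring with 2 hetero atoms), on a nitrogen on an aromatic ring, and the rest of the structure is kept. Among the compounds with values here, one measured step bears on it, at the same place: a 1.8-fold higher number from compound 1 to compound 2 (0.26 log units; within the scatter), which stays within the scatter. One step is thin evidence, but no change beyond the scatter is expected in this assay. The expected step is a 1.2-fold higher number from compound 2 to compound 3 (0.07 log units; within the scatter), with no clear direction. For compound 3 the estimated value is 14 nM, with an expected range from 4 nM to 50 nM as its ends.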

Compound 3, half-maximal inhibitory concentration: 4.54 nM
Estimate against measurement, compound 3: 3.1-fold (0.49 log units) above; measured number inside the range.
By their numbers in this assay, from the lowest: compounds 3, 1 and 2 (each within the scatter of the next, the first and the last beyond it).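

In this assay this position, on a nitrogen on an aromatic ring, now shows a step beyond the scatter: a 2.6-fold lower number from compound 2 to compound 3 (0.42 log units; beyond the scatter) when the open-chain group of 4 heavy atoms replaces 1,3-thiazol-2-yl. Against methyl, the same group gives a 1.4-fold lower number from compound 1 to compound 3 (0.16 log units; within the scatter) and so cannot be told apart from it, which means the ring-free groups sit together here while only compound 3 and compound 2 separate. Nothing measured on these compounds accounts for either step.

Open, as far as these compounds go, is whether a phenyl ring, a plain amine or a longer alkyl chain on this nitrogen would read with compound 3 or with compound 2. From the compounds shown here alone, whether the step from the thiazolyl group holds on other cell lines also remains open.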